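Pyrimidin-2-yl in place of pyridin-3-yl on an amine nitrogen

The compounds below may be only part of what the source reports. "The series", "measured", "known", "first", "only" and "open" are said of these compounds alone.

In a functional assay on CWR22R cells (Homo sapiens) for antiproliferative activity, read by CCK-8 assay, with a stated time of 6 days (a higher number here means a weaker inhibitor, a lower number a stronger inhibitor), compound 1 (`COC(=O)/C=C/C(=O)N[C@@H](C)Cn1ccc(-c2ccc(C#N)c(Cl)c2)n1`) stands as "not determined" (no result reported) and offers no number. In this assay, within the data shown here, compound 2 (`C[C@@H](Cn1ccc(-c2ccc(C#N)c(Cl)c2)n1)Nc1cccnc1`) gives 21600 nM as the only number so far, so its standing against other compounds cannot yet be judged.

Compound 3 (`C[C@@H](Cn1ccc(-c2ccc(C#N)c(Cl)c2)n1)Nc1ncccn1`) keeps the core of compound 2 and differs from it in one place (pyrimidin-2-yl in place of pyridin-3-yl on an amine nitrogen), with pyrimidin-2-yl in place of pyridin-3-yl on an amine nitrogen. Among the measured compounds shown here, no measured step sizes such a change, so no step beyond the scatter is expected, in either direction. The only anchor for the expectation is compound 2 at 21600 nM and the estimate stays close to it. The expected 1.1-fold lower number from compound 2 to compound 3 (0.03 log units; within the scatter) has no firm sign. In this assay the expected value for compound 3 is 20000 nM with a range of 7000 nM to 50000 nM as the estimate.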

Compound 3, half-maximal inhibitory concentration: 12500 nM
Estimate against measurement, compound 3: 1.6-fold (0.20 log units) above; the measured number falls inside the stated range.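

In this assay, among these compounds, the first measured step at this position is a 1.7-fold lower number from compound 2 to compound 3 (0.24 log units; within the scatter), so pyrimidin-2-yl and pyridin-3-yl on the amine nitrogen cannot be told apart. The second ring nitrogen of pyrimidin-2-yl and the change in where the ring is attached therefore leave no resolved mark on the read-out in this pair. This single pair shows that the position accepts either six-membered aromatic ring without a step beyond the scatter, but no data on hand explain that outcome.

Still open, going by these compounds, is whether any group on this amine nitrogen can move the number beyond the scatter. A plain phenyl ring, a pyrazin-2-yl ring or a saturated piperidine ring would test whether the ring nitrogens or the aromatic ring itself matter at this position.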